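The source may hold more compounds than are shown below. What is called first, only, known or untested is meant among the compounds shown, and "the series" means these compounds.

Working notes on the series. In a functional assay on B16-F10 cells (Mus musculus) for antiproliferative activity, read by CCK-8 assay, with a stated time of 48 h (on this read-out higher numbers stand for weaker inhibition and lower numbers for stronger inhibition), compound 1 `COc1ccc(/C=C\c2cc(OC)c(OC)c(OC)c2)cc1OCc1ccc(C=O)cc1` gives 4200 nM. Compound 2 `COc1ccc(/C=C\c2cc(OC)c(OC)c(OC)c2)cc1OCc1ccc(CN2CC[C@H](O)C2)cc1` gives > 10000 nM, which is a limit of the assay and not a number. Its standing therefore rests only on (the limit of > 10000 nM in this assay, at which 1 of the 2 values shown sits).

The next compound is compound 3 `COc1ccc(/C=C\c2cc(OC)c(OC)c(OC)c2)cc1OCc1ccc(CNCCNC(C)=O)cc1`, and the change is (2-acetamidoethyl)amino in place of 3-hydroxypyrrolidin-1-yl on a saturated chain carbon bound to an aromatic carbon. In words, (2-acetamidoethyl)amino stands in place of 3-hydroxypyrrolidin-1-yl on a saturated chain carbon bound to an aromatic carbon, so that (3-hydroxypyrrolidin-1-yl)methyl becomes ((2-acetamidoethyl)amino)methyl.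

Among the measured compounds shown here, only one measured step bears on this substituent: an at least 2.3-fold higher number from compound 1 to compound 2 (0.37 log units; beyond the scatter). As far as these compounds go, that step is beyond the scatter, but it is open-ended and replaces formyl, so it gives no size for exchanging one of these two groups for the other. No change beyond the scatter is therefore expected in this assay, and a report of only a limit would be unsurprising. The expected step is a number no higher from compound 2 to compound 3 (the limit leaves the size open). For compound 3 the estimated value is 10000 nM, with an expected range of 4000 nM to 25000 nM.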

Compound 3, half-maximal inhibitory concentration: 2500 nM
For compound 3 the middle estimate is 4.0-fold (0.60 log units) above the measured one, and the stated range ends above it.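

In this assay, the group on the saturated chain carbon bound to an aromatic carbon turns out to matter, and the loss seen with the first amine does not extend to every amine placed there: the exchange of 3-hydroxypyrrolidin-1-yl for (2-acetamidoethyl)amino gives an at least 4.0-fold lower number from compound 2 to compound 3 (0.60 log units; beyond the scatter). Set against the formyl compound, ((2-acetamidoethyl)amino)methyl gives a 1.7-fold lower number from compound 1 to compound 3 (0.23 log units; within the scatter), so this replacement stays within the scatter, whereas (3-hydroxypyrrolidin-1-yl)methyl gave an at least 2.3-fold higher number from compound 1 to compound 2 (0.37 log units; beyond the scatter). Compound 2 carries only a limit of the assay and not a number, and the step away from it therefore has no upper size: the limit of > 10000 nM in this assay, at which 1 of the 3 values shown sits.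

The exchange removes the ring and its hydroxyl and brings in the acetamide in a single change, so the compounds shown do not separate these parts from one another. As far as these compounds go, whether the acetamide end is needed remains open, and a (2-hydroxyethyl)amino chain, a longer chain ending in the same acetamide, or a piperazine ring at this place would each address a different part of that question.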